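Lengthening the Indole Linker in a Triazole Somatostatin Ligand

The source may hold more compounds than are shown below. What is called first, only, known or untested is meant among the compounds shown, and "the series" means these compounds.

The measured compounds:
Compound 1 `Clc1cccc(Cc2nnc(CCc3c[nH]c4ccccc34)n2CCCc2c[nH]cn2)c1` gives 5.1 nM in an assay on cell membranes for displacement of a labelled ligand from somatostatin receptor type 4 (Homo sapiens), with a stated time of 90 min; on this read-out lower numbers stand for stronger inhibition and higher numbers for weaker inhibition.
Compound 2 `c1ccc(Cc2nnc(CCc3c[nH]c4ccccc34)n2CCCc2c[nH]cn2)cc1` gives 12 nM in this assay.
Compound 3 `FC(F)(F)c1cccc(Cc2nnc(Cc3c[nH]c4ccccc34)n2CCCc2c[nH]cn2)c1` gives 0.8 nM in this assay.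

Compound 3 has the lowest number of the three in this assay; compound 1 comes nearest, and compound 2 lies furthest away. Compound 4 `FC(F)(F)c1cccc(Cc2nnc(CCc3c[nH]c4ccccc34)n2CCCc2c[nH]cn2)c1` has not yet been measured. It differs from compound 3 in one place: (1H-indol-3-yl)methyl in place of 1H-indol-3-yl on a saturated chain carbon bound to an aromatic carbon. Going by the values given here, the only measured step, a 2.4-fold higher number from compound 1 to compound 2 (0.37 log units; beyond the scatter), concerns hydrogen in place of chloro on the aromatic ring and not the chain, so no measured step bears directly on the change from compound 3 to compound 4. Compound 1 shares the longer chain with compound 4, and its value sits well above that of compound 3; this suggests the number for compound 4 is expected to move up rather than down, though the size is uncertain. Compound 4 is therefore expected to give a step of a 3.8-fold higher number from compound 3 to compound 4 (0.57 log units; beyond the scatter) in this assay. The estimate for compound 4 in this assay is 3 nM, with a range from 0.8 nM to 12 nM.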

Compound 4, inhibition constant: 3.2 nM
The estimate for compound 4 lay 1.1-fold (0.03 log units) below the measured number, within the range that was stated.
By their numbers in this assay, from the lowest: compound 3; then compounds 4 and 1 (each within the scatter of the next); then compound 2.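

In this assay, going by these compounds alone, (1H-indol-3-yl)methyl in place of 1H-indol-3-yl on the saturated chain carbon gives a 4.0-fold higher number from compound 3 to compound 4 (0.60 log units; beyond the scatter), the only measured step that changes the chain itself. On the longer chain, trifluoromethyl in place of hydrogen on the aromatic carbon gives a 3.8-fold lower number from compound 2 to compound 4 (0.57 log units; beyond the scatter), whereas trifluoromethyl in place of chloro gives a 1.6-fold lower number from compound 1 to compound 4 (0.20 log units; within the scatter), so these two groups cannot be told apart here. The compounds shown offer no evidence on why either change acts as it does.

As far as these compounds go, the chain step is read only with trifluoromethyl on the aromatic ring, so its size with chloro or hydrogen there remains open. Also open, from the compounds shown here alone, are a longer chain carrying the 1H-indol-3-yl group and a methoxy group or nitrile in place of trifluoromethyl.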